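Return to a benzyl group on the triazole nitrogen

The source may report more compounds than this note shows. Statements on the series, on what has been measured and on what is new or still open speak of the compounds shown alone.

Compound 1 `COc1ccc(Cn2c(CCc3ccccc3)nnc2[C@H](NC(=O)C(C)(C)N)c2c[nH]c3ccccc23)c(OC)c1` gives 60 nM in an in vitro assay on LLC-PK1 cells for displacement of a labelled ligand from growth hormone secretagogue receptor type 1 (Homo sapiens); on this read-out higher numbers stand for weaker inhibition and lower numbers for stronger inhibition. Compound 2 `COc1ccc(Cn2c(CCc3ccccc3)nnc2[C@H](NC(=O)c2ccccn2)c2c[nH]c3ccccc23)c(OC)c1` gives 1.1 nM in this assay, and the step of a 55-fold lower number from compound 1 to compound 2 (1.74 log units; beyond the scatter) is the largest seen in the set. Compound 3 `COc1ccc(-n2c(CCc3ccccc3)nnc2[C@H](NC(=O)c2ccccn2)c2c[nH]c3ccccc23)c(OC)c1` gives 33 nM in this assay; the step of a 30-fold higher number from compound 2 to compound 3 (1.48 log units; beyond the scatter) takes back most of that gain. Compound 3 therefore holds the second highest number of the three: its number is within the scatter of compound 1 and far beyond the scatter from compound 2.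

Compound 4 `CCc1ccc(Cn2c(CCc3ccccc3)nnc2[C@H](NC(=O)c2ccccn2)c2c[nH]c3ccccc23)cc1` carries the change (4-ethylbenzyl in place of 2,4-dimethoxyphenyl on an aromatic nitrogen). The step from compound 1 to compound 2 concerns the carbonyl substituent and does not bear on this change. The step from compound 2 to compound 3 is the relevant one: it exchanged a benzyl for a phenyl group at the same aromatic nitrogen and raised the number strongly. Within the data shown here, compound 4 restores a benzyl, though with a 4-ethyl pattern in place of the 2,4-dimethoxy pattern, which no measured pair tests. A large step downward in this assay is expected, with the expected step of an 11-fold lower number from compound 3 to compound 4 (1.04 log units; beyond the scatter) somewhat short of a full reversal. Compound 4 is therefore expected to give 3 nM, in a range of 0.8 nM to 12 nM.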

Compound 4, half-maximal inhibitory concentration: 67 nM
Estimate against measurement, compound 4: 22-fold (1.35 log units) below; the measured number lies above the stated range.
By their numbers in this assay, from the lowest: compound 2; then compounds 3, 1 and 4 (each within the scatter of the next, the first and the last beyond it).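

The benzyl link on the aromatic nitrogen does not by itself carry the low number in this assay: with the link kept and 4-ethylphenyl in place of 2,4-dimethoxyphenyl on the saturated chain carbon, the result is a 61-fold higher number from compound 2 to compound 4 (1.78 log units; beyond the scatter). Set against the direct aryl attachment, 4-ethylbenzyl brings no gain, giving a 2.0-fold higher number from compound 3 to compound 4 (0.31 log units; beyond the scatter), so among the compounds shown the benefit of the benzyl link appears only with the 2,4-dimethoxy pattern, and the substituents on the ring matter at least as much as the link. Nothing available here accounts for this dependence on the ring substituents.

As far as these compounds go, it remains open whether the higher number of compound 4 reflects the loss of the two methoxy groups or the arrival of the ethyl group, a question that unsubstituted benzyl, 4-methoxybenzyl or 2-methoxybenzyl at this nitrogen could separate. Also open, from the compounds shown here alone, is whether the same dependence holds with the 1-amino-1-methylethyl group of compound 1 on the carbonyl carbon in place of pyridin-2-yl.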